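Aryl exchange on the carbonyl: outlook for compound 3

The compounds below may be only part of what the source reports. "The series", "measured", "known", "first", "only" and "open" are said of these compounds alone.

Measured so far:
compound 1 `CN(C(=O)NC(=O)c1cccc(C(F)(F)F)c1)c1nc(C(F)(F)F)c(C(=O)N/N=C/c2ccc(C(F)(F)F)cc2)s1` – 6.5 ug/mL
compound 2 `CN(C(=O)NC(=O)c1cccc(C(F)(F)F)c1)c1nc(C(F)(F)F)c(C(=O)N/N=C/c2ccccc2C(F)(F)F)s1` – 7.69 ug/mL

In a functional assay on MCF7 cells (Homo sapiens) for inhibition, read by MTT assay, with a stated time of 72 h (on this read-out higher numbers stand for weaker inhibition and lower numbers for stronger inhibition), compound 1 gives 6.5 ug/mL, the lower of the two numbers. Compound 2 gives 7.69 ug/mL; the step of a 1.2-fold higher number from compound 1 to compound 2 (0.07 log units; within the scatter) shows the two as equivalent.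

Compound 3 `CN(C(=O)NC(=O)c1c(F)cccc1F)c1nc(C(F)(F)F)c(C(=O)N/N=C/c2ccc(C(F)(F)F)cc2)s1` differs from compound 1 by 2,6-difluorophenyl in place of 3-(trifluoromethyl)phenyl on a carbonyl carbon. For the measured compounds named here, the only measured step, a 1.2-fold higher number from compound 1 to compound 2 (0.07 log units; within the scatter), sits at a different place and was within the scatter; no measured step touches the aryl on the carbonyl carbon. With no guidance from the series, no change beyond the scatter is expected, a 1.1-fold higher number from compound 1 to compound 3 (0.03 log units; within the scatter). Compound 3 is estimated at 7 ug/mL, range 3 ug/mL to 16 ug/mL.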

Compound 3, half-maximal inhibitory concentration: 35.3 ug/mL
The estimate for compound 3 lay 5.0-fold (0.70 log units) below the measured number; measured number outside the range, above it.
By their numbers in this assay, from the lowest: compounds 1 and 2 (each within the scatter of the next); then compound 3.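

In this assay the aryl on the carbonyl carbon is a position that responds, with a 5.4-fold higher number from compound 1 to compound 3 (0.73 log units; beyond the scatter) for 2,6-difluorophenyl in place of 3-(trifluoromethyl)phenyl, which means weaker inhibition. For the compounds shown here, the only earlier step, at the carbon with a double bond to nitrogen, stayed within the scatter, so of the two places varied so far only this one moves the number. Nothing measured here bears on the reason for this shift.

From the compounds shown here alone, whether a plain phenyl or a 3-methoxyphenyl on the carbonyl carbon would sit with compound 1 or with compound 3 remains open. So does whether the same exchange carries over to compound 2.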